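Carbamoyl on the piperidine ring of compound 3

The source may report more compounds than this note shows. Statements on the series, on what has been measured and on what is new or still open speak of the compounds shown alone.

Measured compounds:
Compound 1 `O=C(CN1CN(c2ccccc2)C2(CCN(C(=O)c3ccc(C4CCCCC4)cc3)CC2)C1=O)NCCCCO`: 10300 nM
Compound 2 `CS(=O)(=O)NCCCNC(=O)CN1CN(c2ccccc2)C2(CCN(C(=O)c3ccc(C4CCCCC4)cc3)CC2)C1=O`: 3800 nM
Compound 3 `O=C(CN1CN(c2ccccc2)C2(CCN(C(=O)c3ccc(C4CCCCC4)cc3)CC2)C1=O)N1CCCCC1`: 1100 nM

In an assay on HEK293 cells for displacement of a labelled ligand from NPC1-like intracellular cholesterol transporter 1 (Homo sapiens) (on this read-out higher numbers stand for weaker inhibition and lower numbers for stronger inhibition), compound 3 stands lowest of the three numbers. Both steps that lead to it are beyond the scatter: a 9.4-fold lower number from compound 1 to compound 3 (0.97 log units; beyond the scatter) and a 3.5-fold lower number from compound 2 to compound 3 (0.54 log units; beyond the scatter). The remaining step, a 2.7-fold lower number from compound 1 to compound 2 (0.43 log units; beyond the scatter), is also beyond the scatter but smaller.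

Compound 4 `NC(=O)C1CCCN(C(=O)CN2CN(c3ccccc3)C3(CCN(C(=O)c4ccc(C5CCCCC5)cc4)CC3)C2=O)C1` keeps the piperidin-1-yl of compound 3 and changes only there: carbamoyl in place of hydrogen on a saturated ring carbon. Within the data shown here, the steps that bear on this are those in which an open-chain amide with a polar end was exchanged for a plain piperidine, and each gave a lower number; a carbamoyl returning on the ring points the other way, though no measured step places such a group on a saturated ring carbon. The expectation is therefore a modest rise in this assay for compound 4, a 2.0-fold higher number from compound 3 to compound 4 (0.30 log units; within the scatter), with wide uncertainty. Compound 4 is estimated at 2200 nM, expected between 700 nM and 7000 nM.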

Compound 4, half-maximal inhibitory concentration: 3100 nM
For compound 4 the middle estimate is 1.4-fold (0.15 log units) below the measured one; the range from low to high includes it.
By their numbers in this assay, from the lowest: compound 3; then compounds 4 and 2 (each within the scatter of the next); then compound 1.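

In this assay, carbamoyl on a saturated ring carbon, two ring bonds from the ring nitrogen, is the only change shown on the piperidine ring itself, and it takes back part of what plain piperidin-1-yl held (a 2.8-fold higher number from compound 3 to compound 4 (0.45 log units; beyond the scatter)). With it, the 3-carbamoylpiperidin-1-yl amide no longer stands apart from the open-chain amide carrying (3-(methanesulfonamido)propyl)amino (a 1.2-fold lower number from compound 2 to compound 4 (0.09 log units; within the scatter)), yet it still stands clear of the one carrying (4-hydroxybutyl)amino (a 3.3-fold lower number from compound 1 to compound 4 (0.52 log units; beyond the scatter)). Nothing measured here accounts for these steps.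

The compounds shown leave open whether a carboxylic acid, an aminomethyl or a hydroxymethyl on the same ring carbon would give a similar number. They also leave open whether a dimethylcarbamoyl there, which has no amide hydrogen, would behave like carbamoyl.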